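A Chloro Group on the Phenyl Ring of Compound 1

The source may hold more compounds than are shown below. What is called first, only, known or untested is meant among the compounds shown, and "the series" means these compounds.

Measured compounds:
compound 1, `COc1ccccc1Oc1c(N)nc(-c2ccccc2)nc1Cl`: 7220 nM
compound 2, `COc1ccccc1Oc1c(N)nc(-c2cccc(C)c2)nc1Cl`: 65300 nM
compound 3, `COc1ccccc1Oc1c(N)nc(-c2ccc(F)cc2)nc1Cl`: 28200 nM

In a functional assay on A-375 cells (Homo sapiens) for cytotoxicity, read by CCK-8 assay, with a stated time of 24 h (on this read-out lower numbers stand for stronger inhibition and higher numbers for weaker inhibition), compound 1 gives 7220 nM, the lowest number of the three and therefore the strongest inhibitor among them, with both other compounds clearly apart from it. Compound 4, `COc1ccccc1Oc1c(N)nc(-c2ccc(Cl)cc2)nc1Cl`, is drawn from compound 1 by a single change: chloro in place of hydrogen on an aromatic carbon. Two measured steps speak to this change, since each also adds one small group to the phenyl ring of compound 1. Adding a methyl gave a 9.0-fold higher number from compound 1 to compound 2 (0.96 log units; beyond the scatter), and adding a fluoro gave a 3.9-fold higher number from compound 1 to compound 3 (0.59 log units; beyond the scatter); between those two products there was a 2.3-fold lower number from compound 2 to compound 3 (0.36 log units; beyond the scatter). Both additions weakened inhibition beyond the usual scatter, so a chloro group is expected to do the same, with the step estimated at a 4.2-fold higher number from compound 1 to compound 4 (0.62 log units; beyond the scatter) toward a higher number. Compound 4 is therefore expected to give about 30000 nM, with a likely range from 10000 nM to 90000 nM.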

Compound 4, half-maximal inhibitory concentration: 1030 nM
The estimate for compound 4 lay 29-fold (1.46 log units) above the measured number; the whole stated range lies above it.
By their numbers in this assay, from the lowest: compound 4; then compound 1; then compound 3; then compound 2.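

In (this assay), the phenyl ring of compound 1 proves able to gain from an added group, not only lose: chloro in place of hydrogen, para to a large group, gives (a 7.0-fold lower number from compound 1 to compound 4 (0.85 log units; beyond the scatter)), opposite in direction to the methyl and fluoro steps. At this one place the identity of the group decides the outcome, since chloro in place of fluoro gives (a 27-fold lower number from compound 3 to compound 4 (1.44 log units; beyond the scatter)). The step (a 63-fold lower number from compound 2 to compound 4 (1.80 log units; beyond the scatter)) is larger still, but it changes both the group and its place on the ring, so it cannot separate those two effects.

Nothing available explains why chloro and fluoro differ so sharply. Open questions are how a bromo, methoxy or amino group would behave at this place, and whether chloro would give the same gain elsewhere on the ring.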